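Heptyl in place of isopropyl on compound 2

The source may hold more compounds than are shown below. What is called first, only, known or untested is meant among the compounds shown, and "the series" means these compounds.

In a functional assay on HCT-116 cells (Homo sapiens) for antiproliferative activity, read by MTT assay, with a stated time of 72 h (on this read-out lower numbers stand for stronger inhibition and higher numbers for weaker inhibition), compound 1 (`CC(C)CNC(=N)NC(=N)Nc1ccc(F)c(F)c1`) gives 29700 nM and compound 3 (`CCN(CC)C(=N)NC(=N)Nc1ccc(F)c(F)c1`) gives 39400 nM as measured values. Compound 2 (`CC(C)NC(=N)NC(=N)Nc1ccc(F)c(F)c1`) reads > 50000 nM as a limit of the assay and not a number. Compound 4 (`CCCCCCCNC(=N)NC(=N)Nc1ccc(F)c(F)c1`) differs from it by heptyl in place of isopropyl on an amine nitrogen. Among the compounds with values here, three measured steps bear on this, all small: an at least 1.6-fold higher number from compound 1 to compound 2 (0.22 log units; that floor lies within the scatter) with isopropyl in place of isobutyl, then a 1.3-fold higher number from compound 1 to compound 3 (0.12 log units; within the scatter) with diethylamino in place of isobutylamino and an at least 1.2-fold lower number from compound 2 to compound 3 (0.10 log units; that floor lies within the scatter) with diethylamino in place of isopropylamino. None reaches a chain as long as heptyl, so a moderate gain is expected in this assay by extension from compound 1 at 29700 nM with its isobutyl. The step expected is an at least 3.3-fold lower number from compound 2 to compound 4 (0.52 log units; beyond the scatter) towards a lower number. Compound 4 is estimated at 15000 nM with an expected range from 5000 nM to 38000 nM for this read-out.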

Compound 4, half-maximal inhibitory concentration: 1800 nM
Compound 4: middle estimate off by 8.3-fold (0.92 log units), on the high side; the measured number lies below the stated range.
By their numbers in this assay, from the lowest: compound 4; then compounds 1 and 3 (each within the scatter of the next). At a limit, above all of these: compound 2.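

On this amine nitrogen, the earlier changes among isopropyl, isobutyl and diethylamino gave only steps within the scatter in this assay, whereas heptyl gives a 17-fold lower number from compound 1 to compound 4 (1.22 log units; beyond the scatter) and an at least 27-fold lower number from compound 2 to compound 4 (1.44 log units; beyond the scatter). The second of these is only a floor, and compound 2 reads as a limit and not a number: the limit of > 50000 nM in this assay, at which 1 of the 4 values shown sits.

From the compounds shown here alone, whether the effect already appears with a pentyl chain, or continues with a longer chain such as decyl, stays open. Also open, going by these compounds, is whether a heptyl chain ending in an amine or a carboxylic acid keeps the lower number.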